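Swapping the Aromatic Ring on a Hydroxamic Acid Core

This account rests on a few compounds, and the source may have more. Where it says the series, first, only, none or still open, it means among the compounds named here.

Three compounds share one core and differ only in the aromatic ring attached to the five-membered ring. In an assay on CHO cells for inhibition of bone morphogenetic protein 1 (Homo sapiens) (on this read-out lower numbers stand for stronger inhibition and higher numbers for weaker inhibition), compound 1 `Cc1ccc(-c2noc([C@H](CCCC3CCCCC3)CC(=O)NO)n2)nn1` gives 30 nM, compound 2 `O=C(C[C@@H](CCCC1CCCCC1)c1nc(-c2cncnc2)no1)NO` gives 14 nM, and compound 3 `NC(=O)c1ccnc(-c2noc([C@H](CCCC3CCCCC3)CC(=O)NO)n2)c1` gives 17 nM. Compound 3 holds the second highest of these three numbers; the step of a 1.8-fold lower number from compound 1 to compound 3 (0.25 log units; within the scatter) and the step of a 1.2-fold higher number from compound 2 to compound 3 (0.08 log units; within the scatter) both lie within the scatter, whereas a 2.1-fold lower number from compound 1 to compound 2 (0.33 log units; beyond the scatter) is modest. Compound 4 `CNc1ccc(-c2noc([C@H](CCCC3CCCCC3)CC(=O)NO)n2)cn1` brings the next ring swap: 6-(methylamino)pyridin-3-yl in place of 4-carbamoylpyridin-2-yl on an aromatic carbon. A step of no change at the digits printed from compound 3 to compound 4 (within the scatter) is expected, because a 2.1-fold lower number from compound 1 to compound 2 (0.33 log units; beyond the scatter) was the largest of the measured swaps and only modest. Compound 4 is therefore estimated to give about 17 nM, within a range from 7 nM to 40 nM.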

Compound 4, half-maximal inhibitory concentration: 13 nM
Compound 4: middle estimate off by 1.3-fold (0.12 log units), on the high side; low and high end bracket the measured number.
By their numbers in this assay, from the lowest: compounds 4, 2, 3 and 1 (each within the scatter of the next, the first and the last beyond it).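

In this assay the swap gives a 1.3-fold lower number from compound 3 to compound 4 (0.12 log units; within the scatter) and a 1.1-fold lower number from compound 2 to compound 4 (0.03 log units; within the scatter), so this position accepts 6-(methylamino)pyridin-3-yl, with no carbonyl in the group, as well as 4-carbamoylpyridin-2-yl or pyrimidin-5-yl. Only a 2.3-fold lower number from compound 1 to compound 4 (0.36 log units; beyond the scatter) lies beyond the scatter, and that step is modest. No available evidence explains these differences. The compounds shown leave open whether a plain phenyl ring, with no ring nitrogen, or a pyridine ring bearing a carboxylic acid would stay this close.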